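A few compounds are considered here, and "the series" means these few. Any claim that something is new, unique, unknown or untested is made for them only; others in the source may bear on it.

Compound 1 `Cc1c(C#N)c(-c2ccccc2)nn1CCCN1CCN(c2cccc(Cl)c2)CC1` and compound 2 `CC(=O)c1cccn1CCCN1CCN(c2ccc(F)cc2)CC1` share the propyl-linked piperazine arm but carry different five-membered heteroaromatic heads. In a functional assay on the whole organism (Abdomen, strain Swiss) for inhibition, with Mus musculus as the target, with stated times of 30 min, 10 min and 5 min, at a dose of 20 mg/kg by the oral route (a higher number here means a stronger effect of the compound at the dose given, a lower number a weaker effect), compound 1 gives 0%, while compound 2 gives 16%, the higher of the two numbers, and the gap between compound 1 and compound 2 lies beyond the usual scatter. Compound 3 `CC(=O)c1cccn1CCCN1CCN(c2cccc(Cl)c2)CC1` keeps the acetylpyrrole head of compound 2 and differs from it in one place: 3-chlorophenyl in place of 4-fluorophenyl on an amine nitrogen in a ring. Among the measured compounds shown here, no step between two measured compounds carries this exact change, so its direction can only be guessed from the surrounding numbers. Since compound 1, which also bears the 3-chlorophenyl, gives 0% in this assay, a modest fall is expected, so that the estimated step of a number 8 percentage points lower from compound 2 to compound 3 (within the scatter) would be small and downward, near the edge of scatter. Compound 3 is therefore expected to give about 8%, with a likely range from 0% to 24%.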

Compound 3, a percentage reported as inhibition, in the whole organism at one dose (the size of the read-out at that dose, not a potency): 41%
Compound 3: the middle estimate sits 33 percentage points below what was measured; measured number above the stated range.
By their numbers in this assay, from the lowest: compound 1; then compound 2; then compound 3.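

With the acetylpyrrole head held fixed, changing the group on the amine nitrogen in the ring from 4-fluorophenyl to 3-chlorophenyl gives a number 25 percentage points higher from compound 2 to compound 3 (beyond the scatter) in this assay, so this position affects the read-out even though the two groups have the same heavy-atom count. The 3-chlorophenyl group does not settle the outcome by itself: with different heads, compound 1 gives 0% and compound 3 gives 41%. Nothing available explains why this change raises the read-out.

The compounds shown leave open whether the step follows the halogen or its place on the ring, which a 3-fluorophenyl or a 4-chlorophenyl group would help to separate. They also leave open how an unsubstituted phenyl group would compare at this position, and each figure comes from a single dose, so none of them is a potency.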